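Benzyl to 4-(tert-butyl)phenyl on the shared core

This account rests on a few compounds, and the source may have more. Where it says the series, first, only, none or still open, it means among the compounds named here.

Of the compounds shown here, two have been measured in a functional assay on MCF7 cells (Homo sapiens) for inhibition, read by CCK-8 assay, with a stated time of 48 h (on this read-out lower numbers stand for stronger inhibition of growth and higher numbers for weaker inhibition of growth), so far. Compound 1 `Cc1ccccc1Nc1nc(NCc2ccncc2)ncc1Cl` gives only a limit in this assay, > 100000 nM, as recorded in the limit of > 100000 nM in this assay, at which 1 of the 2 values shown sits. Within the data shown here, compound 2 `CN1CCN(c2ccc(Nc3ncc(Cl)c(NCc4ccccc4)n3)nc2)CC1` gives 17300 nM in this assay, the only actual number in the set, so it stands as the single point of reference. Compound 3 `CN1CCN(c2ccc(Nc3ncc(Cl)c(Nc4ccc(C(C)(C)C)cc4)n3)nc2)CC1` is not yet measured. It differs from compound 2 in one place: 4-(tert-butyl)phenyl in place of benzyl on a nitrogen on an aromatic ring. Among the measured compounds shown here, no measured pair in this assay shows what such a change does, so the expectation rests on the structural change alone. For compound 3 an improvement in this assay beyond the usual scatter is expected, a step of a 4.9-fold lower number from compound 2 to compound 3 (0.69 log units; beyond the scatter) from the number of compound 2, though the uncertainty is wide. The estimate for compound 3 in this assay is 3500 nM, with a range from 500 nM to 30000 nM.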

Compound 3, concentration for 50% growth inhibition: 12600 nM
The estimate for compound 3 lay 3.6-fold (0.56 log units) below the measured number; low and high end bracket the measured number.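

In this assay, the nitrogen on an aromatic ring of the shared core takes 4-(tert-butyl)phenyl in place of benzyl with a 1.4-fold lower number from compound 2 to compound 3 (0.14 log units; within the scatter), the first paired change read at this position. The two groups are not told apart on this read-out, so this position accepts 4-(tert-butyl)phenyl as readily as benzyl, and the change brings neither a gain nor a loss beyond the usual scatter. No measured property in hand bears on this step.

From the compounds shown here alone, it remains open whether an amine, a carboxylic acid or a longer chain at this position would move the number beyond the scatter. Among these compounds, the other parts of the shared core also remain unresolved: compound 1 differs from compound 2 in more than one place and gives only a limit, so no step to it can be read.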